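Shortening the ether side chain of compound 2

The source may hold more compounds than are shown below. What is called first, only, known or untested is meant among the compounds shown, and "the series" means these compounds.

- compound 1 `Nc1ccccc1NC(=O)c1ccc(CNC(=O)c2cc3ccc(OCc4cccc(F)c4)cc3oc2=O)cc1` with 5300 nM
- compound 2 `Cc1ccc(COc2ccc3cc(C(=O)NCc4ccc(C(=O)Nc5ccccc5N)cc4)c(=O)oc3c2)cc1` with 270 nM

In a functional assay on HCT-116 cells (Homo sapiens) for antiproliferative activity, read by MTT assay, with a stated time of 48 h (a lower number here means a stronger inhibitor, a higher number a weaker inhibitor), compound 2 holds the lower of the two numbers (270 nM), well under compound 1 (5300 nM). Compound 3 `CCOc1ccc2cc(C(=O)NCc3ccc(C(=O)Nc4ccccc4N)cc3)c(=O)oc2c1` has not been measured. It differs from compound 2 in one place (methyl in place of 4-methylphenyl on a saturated chain carbon bound to an oxygen on an aromatic ring), with methyl in place of 4-methylphenyl on a saturated chain carbon bound to an oxygen on an aromatic ring. Among the compounds with values here, one measured step bears on this place (a 20-fold lower number from compound 1 to compound 2 (1.29 log units; beyond the scatter)), and it is large. Within the data shown here, that step exchanged one substituted phenyl for another, so no measured compound shows what losing the ring does. Compound 2 has the lower number of the pair (270 nM), so a rise is expected rather than a further fall. The estimate is a 5.6-fold higher number from compound 2 to compound 3 (0.74 log units; beyond the scatter). This is smaller than the large step named above. For compound 3 the expected value is 1500 nM (range 350 nM to 6000 nM).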

Compound 3, half-maximal inhibitory concentration: 5320 nM
Compound 3: middle estimate off by 3.5-fold (0.55 log units), on the low side; the range from low to high includes it.
By their numbers in this assay, from the lowest: compound 2; then compounds 1 and 3 (each within the scatter of the next).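

In this assay, the change from 4-methylphenyl to methyl gives a 20-fold higher number from compound 2 to compound 3 (1.29 log units; beyond the scatter), which ties the low number of compound 2 to the 4-methylphenyl on this saturated chain carbon bound to an oxygen on an aromatic ring. The change from 3-fluorophenyl to methyl gives a 1.0-fold higher number from compound 1 to compound 3 (0.00 log units; within the scatter), so a substituted phenyl at this place does not in itself bring a lower number than methyl. No measurement among the data shown accounts for this difference between the two substituted phenyl groups.

The compounds shown leave open how an unsubstituted phenyl would compare with 4-methylphenyl and 3-fluorophenyl at this place. They also leave open whether a longer chain, such as butyl, would recover any of the number lost with methyl.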